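Chloro in place of bromo: compound 2 to compound 3

The source may hold more compounds than are shown below. What is called first, only, known or untested is meant among the compounds shown, and "the series" means these compounds.

Two members of the series have been measured in a functional assay on C6 cells (Rattus norvegicus) for cytotoxicity, read by MTT assay, with a stated time of 24 h, tested at 6 ug/mL; a higher number here means a weaker effect of the compound at the concentration tested, a lower number a stronger effect. Compound 1 `Cc1nnc(SCC(=O)N/N=c2/scc(-c3ccc(Cl)cc3)n2-c2ccccc2)s1` gives 82.8% in this assay. Compound 2 `O=C(CSc1ncccn1)N/N=c1/scc(-c2ccc(Br)cc2)n1-c1ccccc1` gives 76.4% in this assay, the lowest of the two numbers, but its nearest neighbour, compound 1, lies within the scatter of it, so no order between the two can be read from these readings.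

Compound 3 `O=C(CSc1ncccn1)N/N=c1/scc(-c2ccc(Cl)cc2)n1-c1ccccc1` has not yet been measured. It differs from compound 2 in one place: chloro in place of bromo on an aromatic carbon. Within the data shown here, no pair of measured compounds shows this change on its own, so there is no measured step to lean on. Compound 1 also carries the chloro group, yet it is not a single step away from compound 3. In this assay compound 1 gives 82.8%, which sits within the scatter of compound 2.

With nothing in the measured pair pointing either way, the estimated step of a number 1.6 percentage points higher from compound 2 to compound 3 (within the scatter) is expected to stay within the scatter, with no direction beyond it. Compound 3 is therefore estimated at 78% in this assay, with a range from 65% to 90%.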

Compound 3, a percentage reported as activity, at one concentration (the size of the read-out at that concentration, not a potency): 95.9%
Compound 3: the middle estimate sits 17.9 percentage points below what was measured; measured number outside the range, above it.
By their numbers in this assay, from the lowest: compounds 2 and 1 (each within the scatter of the next); then compound 3.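

In this assay, among these compounds, the change from 4-bromophenyl to 4-chlorophenyl gives the first reading of a single halogen swap, para to a large group, with pyrimidin-2-yl held on the sulfur: a number 19.5 percentage points higher from compound 2 to compound 3 (beyond the scatter), so the bromo compound has the stronger effect of this pair and the position is not indifferent to which halogen it carries. With the chloro group held, pyrimidin-2-yl in place of 5-methyl-1,3,4-thiadiazol-2-yl on the sulfur gives a number 13.1 percentage points higher from compound 1 to compound 3 (beyond the scatter), which shows that the group on the sulfur also moves the read-out and leaves compound 3 with the weakest effect of the three. The data at hand offer no explanation for either step.

On these data alone, whether the bromo-to-chloro step keeps its size and direction with 5-methyl-1,3,4-thiadiazol-2-yl on the sulfur remains open. So does the reading of a fluoro or methoxy group at the same place on the phenyl ring, and of an amine on the pyrimidine.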